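Anilide to 4-methylbenzyl amide: expected cytotoxicity

The compounds below may be only part of what the source reports. "The series", "measured", "known", "first", "only" and "open" are said of these compounds alone.

Compound 3 `CCOC(=O)[C@@]1(C(=O)Nc2ccccc2)C[C@H]1c1cc(OC)c(OC)c(OC)c1` was tested in a functional assay on SW480 cells (Homo sapiens) for cytotoxicity, read by MTT assay, with a stated time of 48 h (a higher number here means a weaker inhibitor, a lower number a stronger inhibitor), and gave only a limit, > 100000 nM, so no number is known for it. Among its companions, compound 1 `CCOC(=O)[C@@]1(C(=O)Nc2ccccc2Cl)C[C@H]1c1cc(OC)c(OC)c(OC)c1` gives 30100 nM in this assay, and compound 2 `CCOC(=O)[C@]1(C(=O)NCc2ccc(C)cc2)C[C@H]1c1cc(OC)c(OC)c(OC)c1` gives 36400 nM. Among the measured compounds shown here, the one measured step, an at least 3.3-fold higher number from compound 1 to compound 3 (0.52 log units; beyond the scatter), shows that removing the chloro pushes the anilide out of the measurable range (the limit of > 100000 nM in this assay, at which 1 of the 3 values shown sits).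

Compound 4 `CCOC(=O)[C@@]1(C(=O)NCc2ccc(C)cc2)C[C@H]1c1cc(OC)c(OC)c(OC)c1` differs from compound 3 by 4-methylbenzyl in place of phenyl on an amide-type nitrogen. For the measured compounds named here, no measured step covers this exact change. Compound 2 carries the same 4-methylbenzyl amide on a core of the other stereochemistry and gives 36400 nM, a number inside the range of this assay, which suggests the change may bring compound 4 into the measurable range.

Compound 4 is therefore expected to give about 50000 nM in this assay, with a plausible range from 20000 nM to 150000 nM. This means an expected step of an at least 2.0-fold lower number from compound 3 to compound 4 (0.30 log units; that floor lies within the scatter), though a limit remains a real possibility.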

Compound 4, half-maximal inhibitory concentration: > 100000 nM
Compound 4: no number, only a limit; the forecaster's own chance of this, stated with the estimate: 35%; middle value at least 2.0-fold (0.30 log units) away from the limit.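

In this assay compound 4 gives only a limit, > 100000 nM, and the step from compound 3 cannot be read, since both values are limits. The 4-methylbenzyl amide therefore does not by itself secure a measurable value, since changing the drawn configuration at one saturated ring carbon, from R to S, gives an at least 2.7-fold higher number from compound 2 to compound 4 (0.43 log units; beyond the scatter), and the comparison is a clean one: the fact that compounds 2 and 4 differ only in the configuration as drawn. Among the compounds shown here, with the core drawn as in compound 4, the change from 2-chlorophenyl gives an at least 3.3-fold higher number from compound 1 to compound 4 (0.52 log units; beyond the scatter), which leaves compound 1 as the only one of the three compounds drawn this way with a number: the limit of > 100000 nM in this assay, at which 2 of the 4 values shown sit.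

As far as these compounds go, whether a 2-chlorobenzyl group or a longer chain such as 2-phenylethyl on the amide nitrogen would give a number with this configuration remains open. Also open, from the compounds shown here alone, is how the anilides would behave with the other configuration.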